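Compound 4: swapping the aryl group on the amide nitrogen

A few compounds are considered here, and "the series" means these few. Any claim that something is new, unique, unknown or untested is made for them only; others in the source may bear on it.

Compound 1 `O=C(Cn1nc(-c2ccccc2)c2ccccc2c1=O)Nc1ccccc1`: 43000 nM
Compound 2 `COc1ccc(NC(=O)Cn2nc(-c3ccccc3)c3ccccc3c2=O)cc1`: 77000 nM
Compound 3 `COc1ccc(NC(=O)Cn2nc(Cc3ccccc3)c3ccccc3c2=O)cc1`: 62000 nM

In a functional assay on MCF7 cells (Homo sapiens) for antiproliferative activity, read by sulforhodamine B assay, with a stated time of 72 h (on this read-out lower numbers stand for stronger inhibition and higher numbers for weaker inhibition), compound 3 gives 62000 nM, a number within the scatter of both compound 2 and compound 1, so the three measured compounds cannot be told apart. Compound 4 `O=C(Cn1nc(Cc2ccccc2)c2ccccc2c1=O)Nc1cccc(Cl)c1` differs from compound 3 by 3-chlorophenyl in place of 4-methoxyphenyl on an amide-type nitrogen. Within the data shown here, no measured step changes the aryl group on the amide nitrogen in this way; the only step touching that ring, a 1.8-fold higher number from compound 1 to compound 2 (0.25 log units; within the scatter), stayed within the scatter. Removing the methoxy therefore gives no reason to expect a shift beyond the scatter in this assay. Compound 4 is estimated at 45000 nM (range 18000 nM to 110000 nM), a step of a 1.4-fold lower number from compound 3 to compound 4 (0.14 log units; within the scatter) expected to stay within the scatter.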

Compound 4, half-maximal inhibitory concentration: 10800 nM
Compound 4: middle estimate off by 4.2-fold (0.62 log units), on the high side, outside the stated range (below it).
By their numbers in this assay, from the lowest: compound 4; then compounds 1, 3 and 2 (each within the scatter of the next).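

In this assay, the aryl group on the amide nitrogen proves able to move the number: 3-chlorophenyl in place of 4-methoxyphenyl gives a 5.7-fold lower number from compound 3 to compound 4 (0.76 log units; beyond the scatter), whereas the earlier change on this ring, methoxy in place of hydrogen, stayed within the scatter. No evidence is available to explain this shift. Because the methoxy leaves as the chlorine enters, the compounds shown leave open which of the two carries the step. They also leave open how an amine or a carboxylic acid on this ring would read.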